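Replacing the Phenol Hydroxy in Compound 3 with a Urea

The compounds below may be only part of what the source reports. "The series", "measured", "known", "first", "only" and "open" are said of these compounds alone.

Compound 3 `CCCC(Nc1cncc(-c2ccc(O)c(OC)c2)n1)c1cccnc1` gives the lowest number of the three measured compounds in a functional assay on PC-3 cells (Homo sapiens) for cytotoxicity, read by MTT assay, with a stated time of 72 h (a lower number here means a stronger inhibitor, a higher number a weaker inhibitor), with a value of 300 nM. Compound 1 `CCCC(Nc1cncc(-c2ccc(O)c(OC)c2)n1)c1ccc(OC)cc1` gives 3000 nM in this assay, and compound 2 `CCCC(Nc1cncc(-c2ccc(O)c(OC)c2)n1)c1ccc(Cl)cc1` gives 20000 nM. The step of a 10-fold lower number from compound 1 to compound 3 (1.00 log units; beyond the scatter) and the step of a 67-fold lower number from compound 2 to compound 3 (1.82 log units; beyond the scatter) both lie beyond the scatter, as does the step of a 6.7-fold higher number from compound 1 to compound 2 (0.82 log units; beyond the scatter); all three concern the aryl group on the saturated chain carbon, and none touches the other aromatic ring.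

Compound 4 `CCCC(Nc1cncc(-c2ccc(NC(=O)NCC)c(OC)c2)n1)c1cccnc1` differs from compound 3 only at that other ring: (ethylcarbamoyl)amino in place of hydroxy on an aromatic carbon. Within the data shown here, no measured step bears on this position, so the measured steps give no direct guide to the size or direction of the change; they show only that a change elsewhere can move the number by a modest to large amount. Compound 4 is therefore expected to give roughly 1000 nM in this assay, within a wide range from 150 nM to 6000 nM, corresponding to an estimated step of a 3.3-fold higher number from compound 3 to compound 4 (0.52 log units; beyond the scatter).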

Compound 4, half-maximal inhibitory concentration: 40 nM
Estimate against measurement, compound 4: 25-fold (1.40 log units) above, outside the stated range (below it).
By their numbers in this assay, from the lowest: compound 4; then compound 3; then compound 1; then compound 2.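

In this assay, among these compounds, the step of a 7.5-fold lower number from compound 3 to compound 4 (0.88 log units; beyond the scatter) comes from a change at a position that none of the earlier steps touched, on the aromatic carbon ortho to a methoxy group. It shows that, with the pyridin-3-yl group kept in place, the hydroxy is not needed for a low number in this series, and that (ethylcarbamoyl)amino, with its 6 heavy atoms, can stand there in place of a single oxygen and still lower the number beyond the scatter. Nothing at hand explains this step, so the compounds give its size and direction but no reason for it.

What an amine, an acetamide or a urea with a longer chain than ethyl would give at this position remains open, so the compounds shown do not tell which part of the (ethylcarbamoyl)amino group goes with the lower number. Going by these compounds, it is also open whether the same replacement would lower the number when the saturated chain carbon carries the 4-methoxyphenyl group of compound 1 or the 4-chlorophenyl group of compound 2.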